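A few compounds are considered here, and "the series" means these few. Any claim that something is new, unique, unknown or untested is made for them only; others in the source may bear on it.

Three related compounds have so far been tested in a functional assay on MCF7 cells (Homo sapiens) for cytotoxicity, read by sulforhodamine B assay, with a stated time of 48 h (on this read-out higher numbers stand for weaker inhibition of growth and lower numbers for stronger inhibition of growth), and all sit close together. Compound 1 (`Cc1nn(-c2ccccc2)c(Oc2ccc(-c3nc4cc([N+](=O)[O-])ccc4[nH]3)cc2)c1/C=N/NC(N)=S`) gives 9200 nM there, compound 2 (`Cc1nn(-c2ccccc2)c(Sc2ccc(-c3nc4cc(C(=O)O)ccc4[nH]3)cc2)c1/C=N/NC(N)=O`) gives 13600 nM there, and compound 3 (`COc1ccc(N/N=C/c2c(C)nn(-c3ccccc3)c2Oc2ccc(-c3nc4cc(C(N)=O)ccc4[nH]3)cc2)cc1`) gives 13600 nM there. Compound 3 stands level with compound 2, and compound 1 lies within the usual scatter of both, so the three numbers support no ranking.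

Compound 4 (`Cc1nn(-c2ccccc2)c(Oc2ccc(-c3nc4cc(C(N)=O)ccc4[nH]3)cc2)c1/C=N/Nc1ccc([N+](=O)[O-])cc1`) differs from compound 3 in one place (nitro in place of methoxy on an aromatic carbon): nitro in place of methoxy on an aromatic carbon, so that 4-methoxyphenyl becomes 4-nitrophenyl. For the measured compounds named here, no pair of tested compounds shows this change alone. In this assay no step beyond the scatter is expected. An expected slight lean toward lower numbers rests only on compound 1 at 9200 nM and its own nitro group, which sits at a different place. The estimated change reads a 1.4-fold lower number from compound 3 to compound 4 (0.13 log units; within the scatter) and is expected to stay within the scatter. For compound 4 the expected value is 10000 nM with an estimated range from 4500 nM to 22000 nM around it.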

Compound 4, concentration for 50% growth inhibition: 8500 nM
Estimate against measurement, compound 4: 1.2-fold (0.07 log units) above, and the stated range covers the measured number.
By their numbers in this assay, from the lowest: compounds 4, 1, 2 and 3 (each within the scatter of the next).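

In this assay, nitro in place of methoxy on the aromatic carbon para to a large group gives a 1.6-fold lower number from compound 3 to compound 4 (0.20 log units; within the scatter). For the compounds shown here, this pair provides the first direct reading of the change at this position, and it shows that 4-methoxyphenyl and 4-nitrophenyl cannot be told apart on this read-out. No supporting measurement is available to account for this result.

On these data alone, whether an amine, a chlorine atom or a longer alkoxy chain at this position would also stay within the scatter remains open. Going by these compounds alone, with only one pair, it is also open whether the same exchange would read alike with other groups elsewhere on the shared core.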